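Moving from a carboxylic acid to an aminoethyl amide

The source may hold more compounds than are shown below. What is called first, only, known or untested is meant among the compounds shown, and "the series" means these compounds.

Compound 1 `COc1ccc(/C=C\c2cc(OC)c(OC)c(OC)c2)cc1OCc1ccc(CN2CCCC[C@H]2C(=O)O)cc1` was tested in an ADME assay on HEK293 cells (Homo sapiens) for cytotoxicity, read by CCK-8 assay, with a stated time of 48 h; a lower number here means a stronger inhibitor, a higher number a weaker inhibitor. Compound 1 gives > 50000 nM, which is a limit rather than a measured number. A close relative, compound 2 `COc1ccc(/C=C\c2cc(OC)c(OC)c(OC)c2)cc1OCc1ccc(CN2CC[C@@H](O)C2)cc1`, differs only in the group on a saturated chain carbon bound to an aromatic carbon. Compound 2 gives > 50000 nM, again a limit. The step that the two limits leave unreadable from compound 1 to compound 2 therefore cannot be read, and the only firm point is the limit of > 50000 nM in this assay, at which 2 of the 2 values shown sit. The new compound, compound 3 `COc1ccc(/C=C\c2cc(OC)c(OC)c(OC)c2)cc1OCc1ccc(CN2CCCCC2C(=O)NCCN)cc1`, is made from compound 1 by one change (2-((2-aminoethyl)carbamoyl)piperidin-1-yl in place of 2-carboxypiperidin-1-yl on a saturated chain carbon bound to an aromatic carbon). Among the compounds with values here, this is not the same change as that from compound 1 to compound 2, so the single measured step bears on it only in the loose sense that both known neighbours of the shared core sit at the limit. No step beyond the scatter is expected in either direction. Compound 3 is estimated at 50000 nM with a range from 20000 nM to 120000 nM. For compound 3 this means an expected step of a number no higher from compound 1 to compound 3 (the limit leaves the size open), and most likely only a limit would again be reported in this assay.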

Compound 3, half-maximal inhibitory concentration: > 50000 nM
Compound 3: no number, only a limit; the forecaster's own chance of this, stated with the estimate: 70%; the middle value lies on the limit itself.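

Compound 1, compound 2 and compound 3 each give only a limit in this assay, not a number, so no step among them can be read: the limit of > 50000 nM in this assay, at which 3 of the 3 values shown sit.

The compounds shown leave open how far apart the three truly lie, and whether any group at this place on the shared core would give a measurable value in this assay.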